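The compounds below may be only part of what the source reports. "The series", "measured", "known", "first", "only" and "open" are said of these compounds alone.

The measured compounds and their values in a functional assay on SMMC-7721 cells (Homo sapiens) for cytotoxicity, read by MTT assay, with a stated time of 24 h; on this read-out lower numbers stand for stronger inhibition and higher numbers for weaker inhibition:
compound 1, `O=C1/C(=C/c2ccccc2F)CN(S(=O)(=O)c2ccc(O[N+](=O)[O-])cc2)C/C1=C\c1ccccc1F`, 6200 nM
compound 2, `O=C1/C(=C/c2ccccc2F)CN(S(=O)(=O)c2ccc(C(F)(F)F)cc2)C/C1=C\c1ccccc1F`, 5200 nM
compound 3, `O=C1/C(=C/c2ccc(F)cc2)CN(S(=O)(=O)c2ccc(O[N+](=O)[O-])cc2)C/C1=C\c1ccc(F)cc1`, 5000 nM

Compound 4, `O=C1/C(=C/c2ccc(F)cc2)CN(S(=O)(=O)c2ccc(C(F)(F)F)cc2)C/C1=C\c1ccc(F)cc1`, has not yet been measured in this assay. The three measured values all lie within the scatter of one another, so no order among them can be read. The change trifluoromethyl in place of nitrooxy on an aromatic carbon made a 1.2-fold lower number from compound 1 to compound 2 (0.08 log units; within the scatter). The change trifluoromethyl in place of nitrooxy on an aromatic carbon is the same change, at the same place on the ring, but on a different core; how the core of compound 3 differs from the core of compound 1 is not broken down here. Within the data shown here, a step of the same small size is expected this time, a 1.2-fold lower number from compound 3 to compound 4 (0.07 log units; within the scatter), which rests on a 1.2-fold lower number from compound 1 to compound 2 (0.08 log units; within the scatter) alone, since no other pair carries this change. Compound 4 is thus estimated at 4300 nM, with a range from 2000 nM to 9000 nM.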

Compound 4, half-maximal inhibitory concentration: 4400 nM
Beside the measured number, compound 4's estimate is 1.0-fold (0.01 log units) below it; the range from low to high includes it.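

In this assay, trifluoromethyl in place of nitrooxy gives a 1.1-fold lower number from compound 3 to compound 4 (0.06 log units; within the scatter), and the step is of the same small size on both cores: the same change on two cores in this assay, a 1.2-fold lower number (0.08 log units; within the scatter) from compound 1 to compound 2 and a 1.1-fold lower number (0.06 log units; within the scatter) from compound 3 to compound 4, 1.0-fold (0.02 log units) apart, within the scatter of two such steps. The change therefore carries from the core of compound 1 to the core of compound 3 as a step that cannot be told from scatter, and neither pair separates the two groups on this read-out. This does not show that the change has an effect of its own, and two cores say nothing about any others in the series.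

The compounds shown leave open whether an amine, a carboxylic acid or a longer chain at this place on the ring would give a step beyond the scatter. On these data alone, whether the same holds on a core without fluorine also stays open.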